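Phenyl directly on the ring nitrogen: an expected step

A few compounds are considered here, and "the series" means these few. Any claim that something is new, unique, unknown or untested is made for them only; others in the source may bear on it.

Compound 1 `CSc1nc(NCc2ccccc2)c2ccccc2n1` gives 87900 nM in a functional assay on CCRF-CEM cells (Homo sapiens) for cytotoxicity, read by MTT assay, with a stated time of 72 h; a lower number here means a stronger inhibitor of growth, a higher number a weaker inhibitor of growth. Compound 2 `CSc1nc(NCCCCCO)c2ccccc2n1` is reported in this assay only as a limit, > 100000 nM.

Compound 2 therefore stands at the limit of > 100000 nM in this assay, at which 1 of the 2 values shown sits, and its exact position is not known. Compound 3 `CSc1nc(Nc2ccccc2)c2ccccc2n1` differs from compound 2 by phenyl in place of 5-hydroxypentyl on a nitrogen on an aromatic ring. Among the measured compounds shown here, the only measured step that bears on this change is an at least 1.1-fold higher number from compound 1 to compound 2 (0.05 log units; that floor lies within the scatter), where a benzyl chain was swapped for a hydroxyl-bearing chain on the same nitrogen and the number moved little. Both measured compounds sit at the weak end of this assay, so the return of a phenyl, now bound directly to the nitrogen, is expected to give at most a modest move toward a lower number, an at least 1.6-fold lower number from compound 2 to compound 3 (0.22 log units; that floor lies within the scatter), and may well stay within the scatter. Compound 3 is thus expected at about 60000 nM, with a range from 15000 nM to 200000 nM, and a real chance that only a limit is reported.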

Compound 3, concentration for 50% growth inhibition: 74600 nM
For compound 3 the middle estimate is 1.2-fold (0.09 log units) below the measured one; low and high end bracket the measured number.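

Compound 2 is known only as a limit in this assay: the limit of > 100000 nM in this assay, at which 1 of the 3 values shown sits.

The change to phenyl on this nitrogen can therefore be read only as a floor, an at least 1.3-fold lower number from compound 2 to compound 3 (0.12 log units; that floor lies within the scatter), and this shows no change that stands clear of the scatter. What is new is that a phenyl bound directly to the nitrogen gives a measured number: compound 3 gives 74600 nM and compound 1, with its benzyl group, gives 87900 nM, two values within the usual scatter of each other.

As far as these compounds go, the true size of the step from the hydroxypentyl chain remains unknown. Also open, from the compounds shown here alone, is whether a different group on this nitrogen, such as a phenyl carrying a carboxylic acid or a longer chain ending in an amine, would move the number clearly away from this weak end of the assay.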